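The source may hold more compounds than are shown below. What is called first, only, known or untested is meant among the compounds shown, and "the series" means these compounds.

Compounds measured so far:
compound 1, `COc1cccc(N2C(=O)/C(=C/c3cc(C)n(-c4cccc(-c5nnn[nH]5)c4)c3C)SC2=S)c1`, 40600 nM
compound 2, `Cc1cc(/C=C2\SC(=S)N(c3cccc(C(F)(F)F)c3)C2=O)c(C)n1-c1cccc(-c2nnn[nH]2)c1`, 15800 nM

Both numbers come from an ADME assay on MT2 cells (Homo sapiens) for cytotoxicity, read by XTT assay, with a stated time of 4 days; a lower number here means that less compound is tolerated, a higher number that more compound is tolerated. Compound 2 stands as the lowest of the two numbers shown: its nearest neighbour is compound 1, and the step of a 2.6-fold lower number from compound 1 to compound 2 (0.41 log units; beyond the scatter) lies beyond the scatter, so compound 2 is the compound of the pair that is tolerated less.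

Compound 3, `Cc1cc(/C=C2\SC(=S)N(c3cccc(Br)c3)C2=O)c(C)n1-c1cccc(-c2nnn[nH]2)c1`, has not yet been measured in this assay. It differs from compound 2 in one place: bromo in place of trifluoromethyl on an aromatic carbon. The change sits on the same six-membered aromatic ring that carried the earlier change, meta to a large group.

Among the measured compounds shown here, only one measured step exists, a 2.6-fold lower number from compound 1 to compound 2 (0.41 log units; beyond the scatter), and it concerns a different exchange at that ring. For the measured compounds named here, no measured step compares bromo with trifluoromethyl, so there is no direct guide. Going by the values given here, the one step shows that a change at this position can move the number by a modest amount. Compound 3 is therefore expected to stay close to compound 2, with a step of a 1.1-fold higher number from compound 2 to compound 3 (0.06 log units; within the scatter) that should not go beyond the scatter. Compound 3 is estimated at 18000 nM, in a range from 8000 nM to 45000 nM.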

Compound 3, half-maximal cytotoxic concentration: 22600 nM
The estimate for compound 3 lay 1.3-fold (0.10 log units) below the measured number; measured number inside the range.
By their numbers in this assay, from the lowest: compounds 2, 3 and 1 (each within the scatter of the next, the first and the last beyond it).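

In this assay, bromo in place of trifluoromethyl on this aromatic carbon gives a step that stays within the scatter (a 1.4-fold higher number from compound 2 to compound 3 (0.16 log units; within the scatter)), and bromo in place of methoxy does the same (a 1.8-fold lower number from compound 1 to compound 3 (0.25 log units; within the scatter)). The bromo compound therefore cannot be told apart from either of the other two, although those two remain separated by a step beyond the scatter; the three numbers do not fall into clearly distinct levels, and only the exchange between methoxy and trifluoromethyl at this position registers as a measurable difference. No measurement given here offers an explanation for this result.

Going by these compounds, whether a nitrile, an amine or a carboxylic acid on the same aromatic carbon would move the number beyond the scatter from all three compounds, and in which direction, remains open. Also open, on these data alone, is whether these exchanges would read the same on another carbon of that ring, or whether changes elsewhere in the shared core would matter more than any of the changes seen at this position.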